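The source may report more compounds than this note shows. Statements on the series, on what has been measured and on what is new or still open speak of the compounds shown alone.

In an assay for inhibition of Amine oxidase [flavin-containing] B (Rattus norvegicus) (a higher number here means a weaker inhibitor, a lower number a stronger inhibitor), the two measured compounds lie far apart. Compound 2 `COc1cccc(COc2ccc(-c3nn(CCC#N)c(=S)o3)cc2)c1` gives 100 nM in this assay, the lowest number of the two, while compound 1 `N#CCCn1nc(-c2ccc(OCc3ccc([N+](=O)[O-])cc3)cc2)oc1=O` gives 5500 nM in this assay, a gap well beyond the usual scatter. Going by the values given here, no pair of measured compounds differs in only one place, so no single change has a measured step attached to it.

Compound 3 `N#CCCn1nc(-c2ccc(OCc3ccc([N+](=O)[O-])cc3)cc2)oc1=S` has not yet been measured in this assay. Compared with compound 2 it carries a different group on the benzyl part: 4-nitrophenyl in place of 3-methoxyphenyl on a saturated chain carbon bound to an oxygen on an aromatic ring. The same 4-nitrophenyl group is found in compound 1, but compound 1 also differs from compound 2 elsewhere, so its weaker number cannot be laid on this one change alone. Still, that number gives reason to expect compound 3 to come out weaker than compound 2 by a step of a 7.0-fold higher number from compound 2 to compound 3 (0.85 log units; beyond the scatter), a loss beyond the scatter but smaller than the full gap to compound 1. For compound 3 the expected value in this assay is 700 nM, with a range from 120 nM to 4000 nM.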

Compound 3, half-maximal inhibitory concentration: 4300 nM
The estimate for compound 3 lay 6.1-fold (0.79 log units) below the measured number; the whole stated range lies below it.
By their numbers in this assay, from the lowest: compound 2; then compounds 3 and 1 (each within the scatter of the next).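

In this assay, exchanging only the group on a saturated chain carbon bound to an oxygen on an aromatic ring gives a 43-fold higher number from compound 2 to compound 3 (1.63 log units; beyond the scatter), so this one place can move the number by a large amount on its own. Compound 3 and compound 1 both carry the 4-nitrophenyl group and lie within the scatter of each other, so most of the wide gap between compound 2 and compound 1 goes with this group and little with the other difference in their cores. Nothing available here explains why the 4-nitrophenyl group goes with the weaker numbers.

The step changes both the kind of substituent and where it sits on the ring, so the compounds shown cannot separate these two changes; a 3-nitrophenyl or a 4-methoxyphenyl group would pull them apart. Also open, as far as these compounds go, are how a plain phenyl group would compare and whether the 3-methoxyphenyl group would give a similarly low number on the core of compound 1.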